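Amide-to-urea change carried onto a second core

The source may hold more compounds than are shown below. What is called first, only, known or untested is meant among the compounds shown, and "the series" means these compounds.

Compound 1 `COC(=O)/C=C/c1cccc(N(Cc2ccc(/C=C/c3cccc(C(F)(F)F)c3)cc2)C(=O)C(C)C)c1` is the reference point of this small set. In an assay on isolated protein with Bile acid receptor (Homo sapiens) as the target (a higher number here means that more compound is needed for the effect, a lower number that less compound is needed), compound 1 gives 267 nM. Compound 2 `COC(=O)/C=C/c1cccc(N(Cc2ccc(/C=C/c3cccc(C(F)(F)F)c3)cc2)C(=O)NC(C)C)c1` differs from it in one place: isopropylamino in place of isopropyl on a carbonyl carbon. In this assay compound 2 gives 932 nM, so that a 3.5-fold higher number from compound 1 to compound 2 (0.54 log units; beyond the scatter). Compound 3 `COC(=O)/C=C/c1cccc(N(Cc2ccc(/C=C/c3ccc(F)cc3)cc2)C(=O)C(C)C)c1` keeps the isopropylcarbonyl of compound 1 but sits on a different core, the difference being (4-fluorophenyl in place of 3-(trifluoromethyl)phenyl on a double-bonded chain carbon bound to a double-bonded chain carbon). In this assay compound 3 gives 120 nM, and a 2.2-fold lower number from compound 1 to compound 3 (0.35 log units; beyond the scatter); compound 3 therefore has the lowest number of the three measured compounds.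

Compound 4 `COC(=O)/C=C/c1cccc(N(Cc2ccc(/C=C/c3ccc(F)cc3)cc2)C(=O)NC(C)C)c1` repeats on the core of compound 3 the change that compound 2 carries on the core of compound 1: isopropylamino in place of isopropyl on a carbonyl carbon. The place of the change reads the same word for word in both pairs, so this is the same change seen a second time. Because the first occurrence gave a 3.5-fold higher number from compound 1 to compound 2 (0.54 log units; beyond the scatter), a step of similar size is expected here, a 3.5-fold higher number from compound 3 to compound 4 (0.54 log units; beyond the scatter). In this assay compound 4 is accordingly estimated at 420 nM, with a range from 200 nM to 900 nM.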

Compound 4, half-maximal effective concentration: 348 nM
Estimate against measurement, compound 4: 1.2-fold (0.08 log units) above; low and high end bracket the measured number.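

Replacing isopropyl with isopropylamino on a carbonyl carbon gives a 2.9-fold higher number from compound 3 to compound 4 (0.46 log units; beyond the scatter) in this assay, and the step carries over from one core to the other: the same change on two cores in this assay, a 3.5-fold higher number (0.54 log units; beyond the scatter) from compound 1 to compound 2 and a 2.9-fold higher number (0.46 log units; beyond the scatter) from compound 3 to compound 4, 1.2-fold (0.08 log units) apart, within the scatter of two such steps. Read along the other edge of the set, 4-fluorophenyl in place of 3-(trifluoromethyl)phenyl gives a 2.7-fold lower number from compound 2 to compound 4 (0.43 log units; beyond the scatter), and this step likewise keeps its size whether isopropyl or isopropylamino sits on the carbonyl carbon: the same change on two cores in this assay, a 2.2-fold lower number (0.35 log units; beyond the scatter) from compound 1 to compound 3 and a 2.7-fold lower number (0.43 log units; beyond the scatter) from compound 2 to compound 4, 1.2-fold (0.08 log units) apart, within the scatter of two such steps. Across these four compounds the two changes therefore add up without visibly affecting each other, but this rests on only two cores and does not show that the step would hold on any other core, nor does it explain why the number rises.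

The compounds shown leave open whether the same step appears with other groups on the carbonyl carbon, such as a cyclopropyl or a tert-butyl group against a dimethylamino group. On these data alone, it also remains open whether the step keeps its size when a carboxylic acid stands in place of the methyl ester.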